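The source may hold more compounds than are shown below. What is called first, only, known or untested is meant among the compounds shown, and "the series" means these compounds.

In a functional assay on MIA PaCa-2 cells (Homo sapiens) for antiproliferative activity, read by MTT assay, with a stated time of 72 h (a lower number here means that less compound is needed, a higher number that more compound is needed for the effect), compound 1 `CNC(=O)c1cccc(Cn2nc(C)c(NC(=O)c3ccc(COc4ccccc4C)cc3)c2C)c1` gives 2100 nM.
In this assay compound 2 `CNC(=O)c1cccc(Cn2nc(C)c(NC(=O)c3ccc(COc4ccc(C)cc4)cc3)c2C)c1` gives 2600 nM.
In this assay compound 3 `CNC(=O)c1cccc(Cn2nc(C)c(NC(=O)c3ccc(COc4ccccc4Cl)cc3)c2C)c1` gives 6300 nM.

Compound 3 stands highest of the three numbers: the steps of a 3.0-fold higher number from compound 1 to compound 3 (0.48 log units; beyond the scatter) and a 2.4-fold higher number from compound 2 to compound 3 (0.38 log units; beyond the scatter) both lie beyond the scatter, whereas a 1.2-fold higher number from compound 1 to compound 2 (0.09 log units; within the scatter) does not. Compound 4 `CNC(=O)c1cccc(Cn2nc(C)c(NC(=O)c3ccc(COc4cccc(C(F)(F)F)c4)cc3)c2C)c1` differs from compound 3 by 3-(trifluoromethyl)phenyl in place of 2-chlorophenyl on an oxygen on a saturated carbon. Among the compounds with values here, no measured step covers a trifluoromethyl group, so the bearing is indirect: a 3.0-fold higher number from compound 1 to compound 3 (0.48 log units; beyond the scatter) and a 2.4-fold higher number from compound 2 to compound 3 (0.38 log units; beyond the scatter) tie the weakest number to the 2-chlorophenyl group, while a 1.2-fold higher number from compound 1 to compound 2 (0.09 log units; within the scatter) shows a move of a methyl group around the ring costing nothing. A modest lower number is expected for compound 4 because a 2.4-fold higher number from compound 2 to compound 3 (0.38 log units; beyond the scatter) marks the chlorine exchange as the loss, the new group being untested. Compound 4 is therefore estimated at 4000 nM, within 1500 nM to 10000 nM, a step of a 1.6-fold lower number from compound 3 to compound 4 (0.20 log units; within the scatter).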

Compound 4, half-maximal effective concentration: 2300 nM
For compound 4 the middle estimate is 1.7-fold (0.24 log units) above the measured one; the range from low to high includes it.
By their numbers in this assay, from the lowest: compounds 1, 4 and 2 (each within the scatter of the next); then compound 3.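

In this assay, 3-(trifluoromethyl)phenyl on this oxygen undoes the loss seen with 2-chlorophenyl: a 2.7-fold lower number from compound 3 to compound 4 (0.44 log units; beyond the scatter). The new group also stands level with both methyl-bearing rings, with a 1.1-fold lower number from compound 2 to compound 4 (0.05 log units; within the scatter) and a 1.1-fold higher number from compound 1 to compound 4 (0.04 log units; within the scatter), so of the four groups at this place only 2-chlorophenyl stands apart. Nothing available accounts for that difference.
Open, on these data alone, is whether the higher number belongs to chlorine as such or to 2-chlorophenyl alone, which 4-chlorophenyl would test. As far as these compounds go, how a ring carrying an amine or a carboxylic acid would read at this place also stays open.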